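Two Methyls Leave, Two Bromines Enter: Same Toxicity Expected?

This account rests on a few compounds, and the source may have more. Where it says the series, first, only, none or still open, it means among the compounds named here.

Two measured compounds share one core. In a functional assay on C8166 cells (Homo sapiens) for cytotoxicity, read by MTT assay (on this read-out lower numbers stand for higher toxicity in this test and higher numbers for lower toxicity in this test), compound 1 `Cc1cc(S(N)(=O)=O)ccc1NC(=O)COc1ccc(Cl)cc1NC(=O)c1ccccc1C` gives 67300 nM. In the same test compound 2 `Cc1ccc(C(=O)Nc2cc(Cl)ccc2OCC(=O)Nc2ccc(S(N)(=O)=O)cc2C)c(C)c1` gives 47600 nM. For the measured compounds named here, of these two numbers that of compound 2 is the lower, but its only neighbour, compound 1, sits within the scatter: a 1.4-fold lower number from compound 1 to compound 2 (0.15 log units; within the scatter).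

Compound 3 `Cc1cc(S(N)(=O)=O)ccc1NC(=O)COc1ccc(Cl)cc1NC(=O)c1cc(Br)cc(Br)c1` differs from compound 2 by 3,5-dibromophenyl in place of 2,4-dimethylphenyl on a carbonyl carbon. Going by the values given here, the single measured step also touched this ring, and it stayed within the scatter, so nothing yet shows that this ring governs the cytotoxicity read-out. Among the compounds with values here, no measured step covers a swap of this kind, so the expectation rests on that one small step alone. The step expected here is a 1.1-fold higher number from compound 2 to compound 3 (0.02 log units; within the scatter), with no shift beyond the scatter. Compound 3 is therefore estimated to give 50000 nM in this assay, with a range from 20000 nM to 125000 nM.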

Compound 3, half-maximal cytotoxic concentration: 89700 nM
Compound 3: middle estimate off by 1.8-fold (0.25 log units), on the low side; low and high end bracket the measured number.
By their numbers in this assay, from the lowest: compounds 2, 1 and 3 (each within the scatter of the next).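

Across the carbonyl carbon, the change from 2,4-dimethylphenyl to 3,5-dibromophenyl in this assay gives a 1.9-fold higher number from compound 2 to compound 3 (0.28 log units; within the scatter), and the change from 2-methylphenyl to 3,5-dibromophenyl gives a 1.3-fold higher number from compound 1 to compound 3 (0.12 log units; within the scatter). This replaces the groups on the ring with bromine rather than adding a single methyl, yet all three compounds remain within the scatter of one another, so this test does not separate these three groups at this position. No measurement available here points to a cause for this.

Going by these compounds, all three groups are carbon-only aromatic rings bearing methyl or bromine, so it remains open whether an amine or a carboxylic acid on the ring, or a cyclohexyl group in its place, would shift the number beyond the scatter. On these data alone, the rest of the shared core is the same in all three compounds, so its part in this read-out also remains open.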